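Methoxy in place of hydrogen on the saturated chain carbon

This account rests on a few compounds, and the source may have more. Where it says the series, first, only, none or still open, it means among the compounds named here.

Compound 1 `CC[C@@]1(C)C(=O)N(C(=O)NCc2ccccc2)[C@H]1Oc1ccc(C(=O)O)cc1` serves as the anchor of this small set. In an ADME assay for pharmacokinetics (on this read-out lower numbers stand for a shorter-lived compound and higher numbers for a longer-lived compound), compound 1 gives 1.8 h. Two measured neighbours stand close to it. Compound 2 `CC(C)[C@@]1(C)C(=O)N(C(=O)NCc2ccccc2)[C@H]1Oc1ccc(C(=O)O)cc1` gives 2.43 h in this assay, and the step of a 1.4-fold higher number from compound 1 to compound 2 (0.13 log units; within the scatter) remains inside the scatter. Compound 3 `CC[C@]1(C)C(=O)N(C(=O)NCc2ccccc2)[C@H]1Oc1ccc(C(=O)O)cc1` gives 1.89 h, and the step of a 1.1-fold higher number from compound 1 to compound 3 (0.02 log units; within the scatter) is likewise inside the scatter, which fits with the fact that compounds 1 and 3 differ only in the configuration as drawn. Thus the three numbers measured so far cannot be told apart in this assay, and compound 1 sits among them rather than apart from them.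

The next step leads to compound 4 `CC[C@@]1(COC)C(=O)N(C(=O)NCc2ccccc2)[C@H]1Oc1ccc(C(=O)O)cc1`. The change is methoxy in place of hydrogen on a saturated chain carbon bound to a saturated ring carbon. Neither measured step carries a methoxy group, so neither bears directly on this change; the closest is the step from compound 1 to compound 2, which also alters the saturated chain, and it stayed inside the scatter. On that basis no step beyond the scatter is expected in either direction, with a wide margin on account of the absence of any methoxy-bearing comparator. For compound 4 the expected value in this assay is 1.9 h, within a range from 0.9 h to 3.8 h. The step of a 1.1-fold higher number from compound 1 to compound 4 (0.02 log units; within the scatter) is the expected outcome, pending the measurement.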

Compound 4, half-life: 1.81 h
The estimate for compound 4 lay 1.0-fold (0.02 log units) above the measured number, within the range that was stated.
By their numbers in this assay, from the lowest: compounds 1, 4, 3 and 2 (each within the scatter of the next).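

Methoxy in place of hydrogen on a saturated chain carbon bound to a saturated ring carbon reads in this assay as a 1.0-fold higher number from compound 1 to compound 4 (0.00 log units; within the scatter), so methyl to methoxymethyl at this place gives no step that can be told from the scatter. Among these compounds, the earlier one-place change put methyl on a saturated chain carbon bound to a saturated chain carbon and a saturated ring carbon, whereas compound 4 gives the first reading at this other chain carbon and the first for a group carrying oxygen and a hydrogen-bond acceptor, and this reading too stays inside the scatter. No measured property in this set bears on the result for this change.

The compounds shown leave open whether an amine, a hydroxyl group or a longer chain at this place would also stay within the scatter. Among the compounds shown here, they also leave open whether methoxy reads the same on the other drawn configuration, the one carried by compound 3.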